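This account rests on a few compounds, and the source may have more. Where it says the series, first, only, none or still open, it means among the compounds named here.

Of the compounds shown here, three sharing one core have been measured in a functional assay on V79 cells (Cricetulus griseus) for cytotoxicity, read by colony formation; on this read-out lower numbers stand for stronger inhibition and higher numbers for weaker inhibition. Compound 2 (`Cc1c(F)c(N2CCC(N)C2)c(F)c2c1c(=O)c(C(=O)O)cn2C1CC1`) gives 11 ug/mL, the lowest of the three numbers. Compound 3 (`NC1CCN(c2c(F)c(O)c3c(=O)c(C(=O)O)cn(C4CC4)c3c2F)C1`) gives 43 ug/mL, and compound 1 (`Cc1c(F)c(N2CCC(N)C2)c(C(F)(F)F)c2c1c(=O)c(C(=O)O)cn2C1CC1`) gives 290 ug/mL. The next compound, compound 4 (`CCNCC1CCN(c2c(F)c(C)c3c(=O)c(C(=O)O)cn(C4CC4)c3c2F)C1`), keeps the core of compound 2 and differs from it only in the side group: (ethylamino)methyl in place of amino on a saturated ring carbon. That is (ethylamino)methyl in place of amino on a saturated ring carbon.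

Two measured steps provide context, though neither involves this ring. Fluoro in place of trifluoromethyl on an aromatic carbon gave a 26-fold lower number from compound 1 to compound 2 (1.42 log units; beyond the scatter), a large step. Hydroxy in place of methyl on an aromatic carbon gave a 3.9-fold higher number from compound 2 to compound 3 (0.59 log units; beyond the scatter), a modest one. Both show that this read-out can respond to single changes, but neither indicates the direction of the present change. Going by the values given here, no measured pair tests a change at this saturated ring carbon, so the expectation is tentative. Among the compounds with values here, compound 2 holds the lowest number so far, and a modest move towards weaker inhibition is expected. The estimated change is a 1.8-fold higher number from compound 2 to compound 4 (0.26 log units; within the scatter), which may not clear the usual scatter. For compound 4 the expected value is 20 ug/mL, with an estimated range from 5 ug/mL to 80 ug/mL.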

Compound 4, half-maximal inhibitory concentration: 9 ug/mL
Beside the measured number, compound 4's estimate is 2.2-fold (0.35 log units) above it; measured number inside the range.
By their numbers in this assay, from the lowest: compounds 4 and 2 (each within the scatter of the next); then compound 3; then compound 1.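

In this assay, the exchange of 3-aminopyrrolidin-1-yl for 3-((ethylamino)methyl)pyrrolidin-1-yl gave a 1.2-fold lower number from compound 2 to compound 4 (0.09 log units; within the scatter) and so leaves compound 2 and compound 4 indistinguishable on this read-out. Going by these compounds alone, this is the first measured change at this saturated ring carbon, and it shows that the side group can go from 1 heavy atom to 4 heavy atoms, with its hydrogen-bond donor and acceptor counts unchanged, without a step beyond the scatter, whereas the change on an aromatic carbon gave a 26-fold lower number from compound 1 to compound 2 (1.42 log units; beyond the scatter) as a large step. Nothing measured here explains why the larger group leaves the number within the scatter.

Within the data shown here, the single step does not separate the two parts of the change, so it remains open whether aminomethyl or ethylamino alone on this ring carbon would behave in the same way, and whether a side group without nitrogen, such as hydroxy or a plain ethyl chain, would do so too. It also leaves open whether (ethylamino)methyl would give a similar result on the cores of compound 1 and compound 3, which differ from compound 2 on an aromatic carbon.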